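The source may hold more compounds than are shown below. What is called first, only, known or untested is meant among the compounds shown, and "the series" means these compounds.

In a functional assay on MDA-MB-231 cells (Homo sapiens) for inhibition, read by MTT assay, with a stated time of 48 h (a higher number here means a weaker inhibitor of growth, a lower number a stronger inhibitor of growth), compound 1 `S=C(NCc1ccccc1)Nc1ccc2ncnc(Nc3ccc(Oc4ccccc4)cc3)c2c1` gives 6800 nM and compound 2 `Fc1ccc(NC(=S)Nc2ccc3ncnc(Nc4cccc(Br)c4)c3c2)cc1Cl` gives 300 nM as the lower of the two numbers. This makes compound 2 the stronger growth inhibitor of the pair, by a gap beyond the usual scatter. The two compounds differ in more than one place, so that gap cannot be pinned on any single group. Compound 3 `S=C(Nc1ccc(Cl)c(Cl)c1)Nc1ccc2ncnc(Nc3cccc(Br)c3)c2c1` departs from compound 2 at one spot only, with chloro in place of fluoro on an aromatic carbon, turning 3-chloro-4-fluorophenyl into 3,4-dichlorophenyl. For the measured compounds named here, compound 2 at 300 nM is the closest measured reference and no measured pair shows what this swap does, so no change beyond the scatter is expected in this assay in either direction. The expected step of no change at the digits printed from compound 2 to compound 3 (within the scatter) is therefore small. Compound 3 is estimated at 300 nM with 100 nM to 900 nM as the likely range.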

Compound 3, concentration for 50% growth inhibition: 4800 nM
Compound 3: the middle estimate sits 16-fold (1.20 log units) below what was measured; the measured number lies above the stated range.
By their numbers in this assay, from the lowest: compound 2; then compounds 3 and 1 (each within the scatter of the next).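

In this assay, for the compounds shown here, this is the first change at a single place, and the exchange of one halogen for another gives a 16-fold higher number from compound 2 to compound 3 (1.20 log units; beyond the scatter) while the rest of the structure stays the same. The position on the aromatic ring, para to a large group and ortho to a chloro group, is therefore sensitive to its substituent, with fluoro here giving the much stronger growth inhibition of the two. No measurement at hand explains why a one-atom exchange has so large an effect.

On these data alone, what hydrogen, a methyl group or a methoxy group would do at this position remains open. It is also unknown whether the same exchange would give a similar step in a compound that differs elsewhere.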